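Methyl on the shared core: a step to be measured

The source may report more compounds than this note shows. Statements on the series, on what has been measured and on what is new or still open speak of the compounds shown alone.

Of the compounds shown here, three have been tested in a functional assay on MCF7 cells (Homo sapiens) for antiproliferative activity, read by MTT assay, with a stated time of 48 h; on this read-out lower numbers stand for stronger inhibition and higher numbers for weaker inhibition. Compound 1 `Cc1ccc2nc(Nc3nc(Nc4ccc(S(N)(=O)=O)cc4)ncc3C)sc2c1` and compound 2 `Cc1cnc(Nc2ccc(S(N)(=O)=O)cc2)nc1Nc1nc2ccccc2s1` share a core that differs from the core of compound 3 `CS(=O)(=O)c1ccc(Nc2nccc(Nc3nc4ccccc4s3)n2)cc1`; how the two cores differ is not broken down here. Compound 4 `Cc1ccc2nc(Nc3ccnc(Nc4ccc(S(C)(=O)=O)cc4)n3)sc2c1` has not yet been measured.

In this assay compound 1 reaches only the limit of the assay, > 50000 nM. Compound 2 likewise gives only a limit, > 50000 nM, not a number. Among the measured compounds shown here, compound 3 is the one compound with a number, giving 10600 nM.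

Compound 2 and compound 1 differ in one place (methyl in place of hydrogen on an aromatic carbon). The step between them, a step that the two limits leave unreadable from compound 2 to compound 1, cannot be read because the limit of > 50000 nM in this assay, at which 2 of the 3 values shown sit, hides both ends. Compound 3 and compound 4 differ in the same way (methyl in place of hydrogen on an aromatic carbon), at the same place: this is the same change, made on a different core.

For the measured compounds named here, since the one measured example of this change gives no readable size, there is no measured step to carry over. Going by the values given here, the expectation therefore rests on compound 3 alone, whose value of 10600 nM is the only number available, and on the smallness of the change, a single methyl replacing a hydrogen. The expected step is a 1.1-fold lower number from compound 3 to compound 4 (0.03 log units; within the scatter), essentially no movement beyond the usual scatter. Compound 4 is thus expected to give about 10000 nM, with a range from 4000 nM to 30000 nM.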

Compound 4, half-maximal inhibitory concentration: > 50000 nM
Compound 4: only a limit was reported (the forecaster's own chance of this, stated with the estimate: 15%); at least 5.0-fold (0.69 log units) between middle value and limit.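

From the compounds shown here alone, on the core of compound 3, putting methyl in place of hydrogen on an aromatic carbon gives in this assay an at least 4.7-fold higher number from compound 3 to compound 4 (0.67 log units; beyond the scatter), so on this core the small change weakens the measured inhibition, and its full size remains unknown. Among the compounds shown here, the same change on the core shared by compound 1 and compound 2 cannot be read, so there is no second measured step to set beside this one, and the data cannot say whether the change has a similar size on both cores: the step on that core is hidden because of the limit of > 50000 nM in this assay, at which 3 of the 4 values shown sit. The result therefore shows that a change with no readable effect on one core can have a clear effect on another, but it does not show that the two cores respond differently, and it gives no measured reason for the loss.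

For the compounds shown here, compound 3, at 10600 nM, is the only compound here with a number, so it is the one reference point for further changes at this aromatic carbon. Going by these compounds, whether a different group in this place, such as an amine, a carboxylic acid or a longer chain, would keep, improve or lose that activity remains open.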